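Another Pyrimidine on the Sulfonamide Nitrogen

A few compounds are considered here, and "the series" means these few. Any claim that something is new, unique, unknown or untested is made for them only; others in the source may bear on it.

Measured in a functional assay on T47D cells (Homo sapiens) for cytotoxicity, read by sulforhodamine B assay, with a stated time of 48 h; on this read-out lower numbers stand for stronger inhibition and higher numbers for weaker inhibition:
Compound 1, `N=C(N)NS(=O)(=O)c1ccc(N/C=C\C(=O)c2cc3ccccc3oc2=O)cc1`, gives 87600 nM.
Compound 2, `Cc1cc(NS(=O)(=O)c2ccc(N/C=C\C(=O)c3cc4ccccc4oc3=O)cc2)on1`, gives 75600 nM.
Compound 3, `Cc1cc(NS(=O)(=O)c2ccc(N/C=C\C(=O)c3cc4ccccc4oc3=O)cc2)nc(C)n1`, gives 100000 nM.

Compound 3 holds the highest of the three numbers, but its separation from the other two is small: the step of a 1.1-fold higher number from compound 1 to compound 3 (0.06 log units; within the scatter) and the step of a 1.3-fold higher number from compound 2 to compound 3 (0.12 log units; within the scatter) both fall within the scatter, as does a 1.2-fold lower number from compound 1 to compound 2 (0.06 log units; within the scatter). The three compounds share one core and differ only in the group carried on the sulfonamide nitrogen.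

Compound 4, `COc1cnc(NS(=O)(=O)c2ccc(N/C=C\C(=O)c3cc4ccccc4oc3=O)cc2)nc1`, is not yet measured. It differs from compound 3 by 5-methoxypyrimidin-2-yl in place of 2,6-dimethylpyrimidin-4-yl on a sulfonamide nitrogen. All three measured steps concern exchanges at this same nitrogen, and none of them moved the number beyond the scatter, so the same is expected here: the estimated step of a 1.1-fold lower number from compound 3 to compound 4 (0.05 log units; within the scatter) in this assay is expected to stay within the scatter. On that basis compound 4 is expected to give about 90000 nM, with a range from 45000 nM to 180000 nM.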

Compound 4, half-maximal inhibitory concentration: 8800 nM
Compound 4: middle estimate off by 10-fold (1.01 log units), on the high side; the measured number lies below the stated range.
By their numbers in this assay, from the lowest: compound 4; then compounds 2, 1 and 3 (each within the scatter of the next).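

In this assay, the sulfonamide nitrogen proved able to carry a change beyond the scatter, which no exchange among compounds 1, 2 and 3 had done, and the step (an 11-fold lower number from compound 3 to compound 4 (1.06 log units; beyond the scatter)) joins two groups that each hold one six-membered aromatic ring with 2 hetero atoms. The other two steps (an 8.6-fold lower number from compound 2 to compound 4 (0.93 log units; beyond the scatter)) and (a 10-fold lower number from compound 1 to compound 4 (1.00 log units; beyond the scatter)) also lie beyond the scatter, so compound 4 is the most potent of the four here, while the other three stay within the scatter of one another. No evidence is at hand that bears on this result.

Open, as far as these compounds go, is whether the lower number goes with the methoxy group or with the pyrimidin-2-yl attachment, since 5-methoxypyrimidin-2-yl and 2,6-dimethylpyrimidin-4-yl differ in both. Also open, from the compounds shown here alone, is how a plain pyrimidin-2-yl or a 5-ethoxypyrimidin-2-yl group would read on this nitrogen.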